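The source may hold more compounds than are shown below. What is called first, only, known or untested is meant among the compounds shown, and "the series" means these compounds.

Of the compounds shown here, three have so far been measured in an assay on HEK293 cells for antagonist activity at P2X purinoceptor 7 (Homo sapiens), read by fluorescence, with a stated time of 2 h; on this read-out lower numbers stand for stronger inhibition and higher numbers for weaker inhibition. Compound 1 `O=C(c1ccc(Cl)c(C(F)(F)F)c1)N1CCC(n2cncc2-c2ccc(OS(=O)(=O)c3ccccc3)cc2)CC1` gives 702 nM, compound 2 `O=C(c1ccc(Cl)c(C(F)(F)F)c1)N1CCC(n2cncc2-c2ccc(OS(=O)(=O)c3cccs3)cc2)CC1` gives 238 nM, and compound 3 `N#Cc1cccc(S(=O)(=O)Oc2ccc(-c3cncn3C3CCN(C(=O)c4ccc(Cl)c(C(F)(F)F)c4)CC3)cc2)c1` gives 73 nM, the lowest of the three numbers, set apart by the steps of a 9.6-fold lower number from compound 1 to compound 3 (0.98 log units; beyond the scatter) and a 3.3-fold lower number from compound 2 to compound 3 (0.51 log units; beyond the scatter). Compound 4 `CNC(=O)c1cccc(S(=O)(=O)Oc2ccc(-c3cncn3C3CCN(C(=O)c4ccc(Cl)c(C(F)(F)F)c4)CC3)cc2)c1` differs from compound 3 only in methylcarbamoyl in place of cyano on an aromatic carbon. Among the compounds with values here, no measured step exchanges a cyano for an amide; the nearest guides are a 9.6-fold lower number from compound 1 to compound 3 (0.98 log units; beyond the scatter), which shows that the group on that aromatic carbon changes the number, and a 2.9-fold lower number from compound 1 to compound 2 (0.47 log units; beyond the scatter), which shows that the sulfonyl ring itself does too. A modest shift in either direction is plausible. Compound 4 is expected to give 150 nM, within 50 nM to 500 nM, an estimate that means a 2.1-fold higher number from compound 3 to compound 4 (0.31 log units; beyond the scatter).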

Compound 4, half-maximal inhibitory concentration: 112 nM
Compound 4: middle estimate off by 1.3-fold (0.13 log units), on the high side, within the range that was stated.
By their numbers in this assay, from the lowest: compounds 3 and 4 (each within the scatter of the next); then compound 2; then compound 1.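

Exchanging cyano for methylcarbamoyl, which has more heavy atoms and adds a hydrogen-bond donor, leaves the number within the scatter (a 1.5-fold higher number from compound 3 to compound 4 (0.19 log units; within the scatter)). The gain over the unsubstituted ring therefore does not depend on cyano alone (a 6.3-fold lower number from compound 1 to compound 4 (0.80 log units; beyond the scatter)), and the 3-(methylcarbamoyl)phenyl group still surpasses thiophen-2-yl (a 2.1-fold lower number from compound 2 to compound 4 (0.33 log units; beyond the scatter)). No available evidence explains why these two groups read alike. From the compounds shown here alone, whether the amide hydrogen matters remains open, as a dimethylcarbamoyl group would test. So does the effect of a carboxylic acid or an amine on this carbon.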